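Benzylsulfonyl for cyclopropylcarbonyl on compound 3

The compounds below may be only part of what the source reports. "The series", "measured", "known", "first", "only" and "open" are said of these compounds alone.

Compound 1 (`C#CCOc1cc(/C=C/C(=O)c2ccc(OC)c3c2OC(C)(C)C=C3)ccc1OC`) gives > 10000 nM in a functional assay on K562 cells (Homo sapiens) for cytotoxicity, read by MTT assay (on this read-out higher numbers stand for weaker inhibition and lower numbers for stronger inhibition), and this value is a limit of the assay. In this assay compound 2 (`CCC(=O)Oc1cc(/C=C/C(=O)c2ccc(OC)c3c2OC(C)(C)C=C3)ccc1OC`) gives 160 nM and compound 3 (`COc1ccc(/C=C/C(=O)c2ccc(OC)c3c2OC(C)(C)C=C3)cc1OC(=O)C1CC1`) gives 410 nM as the higher of the two actual numbers. Its nearest neighbour is compound 2, and a 2.6-fold higher number from compound 2 to compound 3 (0.41 log units; beyond the scatter) is a modest step beyond the scatter.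

Compound 4 (`COc1ccc(/C=C/C(=O)c2ccc(OC)c3c2OC(C)(C)C=C3)cc1OS(=O)(=O)Cc1ccccc1`) carries benzylsulfonyl in place of cyclopropylcarbonyl on an oxygen on an aromatic ring. Among the compounds with values here, no measured step covers this exchange directly. The closest guide is the change of the group on the carbonyl carbon, a 2.6-fold higher number from compound 2 to compound 3 (0.41 log units; beyond the scatter), which moved the number only modestly. The large steps of an at least 62-fold lower number from compound 1 to compound 2 (1.79 log units; beyond the scatter) and an at least 24-fold lower number from compound 1 to compound 3 (1.38 log units; beyond the scatter) show how far the number can move when the group on this oxygen changes, so a much weaker outcome cannot be excluded. Benzylsulfonyl also differs more from cyclopropylcarbonyl than the two carbonyl groups differ from each other, which calls for a wide range. The expected change is a 2.4-fold higher number from compound 3 to compound 4 (0.39 log units; beyond the scatter), a modest move towards weaker inhibition. For compound 4 the estimated value is 1000 nM, with an expected range of 200 nM to 6000 nM.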

Compound 4, half-maximal inhibitory concentration: > 10000 nM
Compound 4 gave a limit, no number; the forecaster's own chance of this, stated with the estimate: 12%; at least 10-fold (1.00 log units) between middle value and limit.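

With an at least 24-fold higher number from compound 3 to compound 4 (1.38 log units; beyond the scatter) and an at least 62-fold higher number from compound 2 to compound 4 (1.79 log units; beyond the scatter), the low numbers seen in this assay with propanoyl and cyclopropylcarbonyl on this oxygen do not carry over to benzylsulfonyl. Compound 4 gives > 10000 nM, which is a limit of the assay and not a number. Among the compounds shown, low numbers therefore belong only to the two groups with a carbonyl on this oxygen, while compound 1 and compound 4 go against any wider reading, and the step between these two cannot be read: the limit of > 10000 nM in this assay, at which 2 of the 4 values shown sit.

Benzylsulfonyl changes both the link to the oxygen and the group at its end, so these compounds do not separate the sulfonyl link from the benzyl part; a methylsulfonyl group or a phenylacetyl group on the same oxygen would divide the two. Also open, going by these compounds, is how much room the carbonyl groups leave on this oxygen, for instance with a benzoyl group or a longer acyl chain, and how a free hydroxyl at this place would compare.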